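A few compounds are considered here, and "the series" means these few. Any claim that something is new, unique, unknown or untested is made for them only; others in the source may bear on it.

The measured compounds are compound 1 `O=C(N/N=C/c1ccc(F)cc1)Nc1ccc(Oc2ccnc3[nH]ccc23)c(F)c1` with 3880 nM, compound 2 `O=C(N/N=C/c1ccc(F)cc1)Nc1ccc(Oc2ccnc3[nH]ccc23)cc1` with 3430 nM, and compound 3 `O=C(N/N=C/c1ccc(O)cc1)Nc1ccc(Oc2ccnc3[nH]ccc23)cc1` with 32200 nM, all in a functional assay on HepG2 cells (Homo sapiens) for antiproliferative activity, read by MTT assay, with a stated time of 72 h; a lower number here means a stronger inhibitor, a higher number a weaker inhibitor.

Compound 1 stands second highest of these three numbers; its nearest neighbour is compound 2, reached by a 1.1-fold lower number from compound 1 to compound 2 (0.05 log units; within the scatter), and its furthest is compound 3. Compound 4 `CN(C)CCn1cccc1/C=N/NC(=O)Nc1ccc(Oc2ccnc3[nH]ccc23)c(F)c1` differs from compound 1 in one place: 1-(2-(dimethylamino)ethyl)-1H-pyrrol-2-yl in place of 4-fluorophenyl on a carbon with a double bond to nitrogen. For the measured compounds named here, no measured step exchanges this whole ring. The two known steps only alter a substituent on it: a 1.1-fold lower number from compound 1 to compound 2 (0.05 log units; within the scatter), and a 9.4-fold higher number from compound 2 to compound 3 (0.97 log units; beyond the scatter). The second shows that a change at this ring can move the number by a modest amount in this assay, so a step of that order, in either direction, is possible here. Compound 4 is therefore expected not far from compound 1, at a 1.3-fold lower number from compound 1 to compound 4 (0.11 log units; within the scatter). The estimate for compound 4 is 3000 nM, with a range from 700 nM to 13000 nM.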

Compound 4, half-maximal inhibitory concentration: 8980 nM
Compound 4: middle estimate off by 3.0-fold (0.48 log units), on the low side; the measured number falls inside the stated range.
By their numbers in this assay, from the lowest: compounds 2 and 1 (each within the scatter of the next); then compound 4; then compound 3.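

In this assay, exchanging the whole 4-fluorophenyl ring for 1-(2-(dimethylamino)ethyl)-1H-pyrrol-2-yl gives a 2.3-fold higher number from compound 1 to compound 4 (0.36 log units; beyond the scatter). The earlier steps shown here altered only a substituent on the ring, whereas this one shows that a five-membered aromatic ring carrying a basic-named side chain can stand at this carbon with a modest weakening. Nothing measured here accounts for this step.

The compounds shown leave open whether the pyrrole ring or the 2-(dimethylamino)ethyl chain sets this step. A plain 1H-pyrrol-2-yl group, or a morpholine in place of the dimethylamino group, would bear on that question.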